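A few compounds are considered here, and "the series" means these few. Any claim that something is new, unique, unknown or untested is made for them only; others in the source may bear on it.

In a functional assay on CHO cells for agonist activity at metabotropic glutamate receptor 2 (Homo sapiens), read by GTPgammaS binding (on this read-out lower numbers stand for an effect already at smaller amounts and higher numbers for an effect only at larger amounts of compound), three analogues sharing a fused core have been measured. Compound 3 `N#Cc1c(-c2cc(Cl)c3c(ccn3CC3CC3)c2)ccn2c(CC(F)(F)F)cnc12` gives 110 nM. Compound 1 `FC(F)(F)Cc1cnc2c(Cl)c(-c3cc(Cl)c4c(ccn4CC4CC4)c3)ccn12` gives 250 nM in this assay. Compound 2 `N#Cc1c(-c2ccc3c(ccn3[C@H]3CC[C@H](O)CC3)c2)ccn2c(CC(F)(F)F)cnc12` carries a core that differs from that of compound 3 in a way not broken down here. Compound 2 gives 330 nM. The values of compound 2 and compound 1 lie within the scatter of each other. Among the compounds with values here, the one counted change, (chloro in place of cyano on an aromatic carbon), produced a 2.3-fold higher number from compound 3 to compound 1 (0.36 log units; beyond the scatter), a modest loss.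

Compound 4 `O[C@H]1CC[C@H](n2ccc3cc(-c4ccn5c(CC(F)(F)F)cnc5c4Cl)ccc32)CC1` remains to be measured. It stands to compound 2 as compound 1 stands to compound 3, the change being (chloro in place of cyano on an aromatic carbon), the same change at the same place. Within the data shown here, for compound 4 the expected step is a 2.1-fold higher number from compound 2 to compound 4 (0.33 log units; beyond the scatter), because the earlier step of a 2.3-fold higher number from compound 3 to compound 1 (0.36 log units; beyond the scatter) on the core of compound 3 is the only guide available, and nothing shows whether the core of compound 2 would respond alike. On that basis compound 4 is expected to give about 700 nM, most likely between 350 nM and 1500 nM.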

Compound 4, half-maximal effective concentration: 160 nM
Compound 4: the middle estimate sits 4.4-fold (0.64 log units) above what was measured, outside the stated range (below it).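

In this assay, chloro in place of cyano on the aromatic carbon gave a 2.1-fold lower number from compound 2 to compound 4 (0.31 log units; beyond the scatter), which runs in the opposite direction to the earlier step, and the two steps clearly differ: the same change on two cores in this assay, a 2.3-fold higher number (0.36 log units; beyond the scatter) from compound 3 to compound 1 and a 2.1-fold lower number (0.31 log units; beyond the scatter) from compound 2 to compound 4, 4.7-fold (0.67 log units) apart, beyond the scatter of two such steps This shows that, among these two pairs, the effect of the change did not carry from one core to the other, so a step seen on one core is a poor guide to the next. It does not show which feature of the two cores accounts for the reversal, since they differ in a way not broken down here, and two pairs cannot show which of the two behaviours is the more usual in the series.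

The compounds shown leave open how a methyl or a bromo on that same aromatic carbon would compare with chloro and cyano on either core. They also leave open which way the change would run on a core bearing an amine or a carboxylic acid in place of the hydroxyl group of compound 2 and compound 4.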